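Dropping the trifluoromethyl from the benzamide of compound 1

The source may report more compounds than this note shows. Statements on the series, on what has been measured and on what is new or still open speak of the compounds shown alone.

Compound 1 `COc1cc(-c2nn(-c3cccc(NC(=O)c4cccc(C(F)(F)F)c4)c3)cc2-c2ccncc2)ccc1Cl` and compound 2 `O=C(Nc1cccc(-n2cc(-c3ccncc3)c(-c3ccc(Cl)c(O)c3)n2)c1)Nc1cc(C(F)(F)F)cc(C(F)(F)F)c1` share a core and were tested in a functional assay on HOP-92 cells (Homo sapiens) for inhibition, read by sulforhodamine B assay, with a stated time of 48 h; on this read-out higher numbers stand for weaker inhibition of growth and lower numbers for stronger inhibition of growth. Compound 1 gives 3120 nM in this assay. Compound 2 gives 1750 nM in this assay, and the two numbers lie within the usual scatter of each other, so neither compound can be said to inhibit growth more strongly than the other on this evidence. Compound 3 `COc1cc(-c2nn(-c3cccc(NC(=O)c4ccccc4)c3)cc2-c2ccncc2)ccc1Cl` has not been measured. It differs from compound 1 in one place: hydrogen in place of trifluoromethyl on an aromatic carbon. Going by the values given here, no measured pair in this set carries the same change, so the size of its effect cannot be read from the data. The step from compound 1 to compound 3 is therefore expected to be modest and, if anything, toward weaker inhibition of growth, with a 1.6-fold higher number from compound 1 to compound 3 (0.20 log units; within the scatter) as the estimated shift. Compound 3 is expected to give about 5000 nM in this assay, within a range from 2000 nM to 12500 nM.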

Compound 3, concentration for total growth inhibition: 4710 nM
Estimate against measurement, compound 3: 1.1-fold (0.03 log units) above; low and high end bracket the measured number.
By their numbers in this assay, from the lowest: compounds 2, 1 and 3 (each within the scatter of the next, the first and the last beyond it).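

In this assay, hydrogen in place of trifluoromethyl on this aromatic carbon gives a 1.5-fold higher number from compound 1 to compound 3 (0.18 log units; within the scatter), the first step read at this position. The two groups therefore cannot be told apart here on this read-out, and the 3-(trifluoromethyl)phenyl of compound 1 is not needed for compound 3 to give a number in the same range. Nothing measured alongside these compounds speaks to the reason for this result. As far as these compounds go, whether another group on this aromatic carbon, such as an amine or a carboxylic acid, would shift the number beyond the scatter remains open. Also open, from the compounds shown here alone, is whether hydrogen in place of trifluoromethyl would have the same small effect on the two trifluoromethyl groups of compound 2, where no such step can be read.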